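This account rests on a few compounds, and the source may have more. Where it says the series, first, only, none or still open, it means among the compounds named here.

Working notes on the series.

Compound 1, `CCCCOC(=O)c1cc(N2C(=O)C3=C(CCCC3)C2=O)ccc1Cl`, is the reference point. In a functional assay on the whole organism with Scenedesmus acutus as the target (a lower number here means a stronger inhibitor, a higher number a weaker inhibitor), compound 1 gives 3550 nM. Compound 2, `CCCCOC(=O)c1cc(N2C(=O)C3=C(CCCC3)C2=O)c(F)cc1Cl`, differs from it by fluoro in place of hydrogen on an aromatic carbon, and in this assay compound 2 gives 67.6 nM; the step is a 53-fold lower number from compound 1 to compound 2 (1.72 log units; beyond the scatter). Compound 3, `C#CCOc1cc(N2C(=O)C3=C(CCCC3)C2=O)ccc1Cl`, carries a different core: the difference between the two cores is propargyloxy in place of butoxycarbonyl on an aromatic carbon. In this assay compound 3 gives 79.4 nM, a step of a 45-fold lower number from compound 1 to compound 3 (1.65 log units; beyond the scatter). Compound 2 and compound 3 sit within the scatter of each other, so no order between them is claimed.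

Compound 4, `C#CCOc1cc(N2C(=O)C3=C(CCCC3)C2=O)c(F)cc1Cl`, is not yet measured. It differs from compound 3 by fluoro in place of hydrogen on an aromatic carbon. This is the same kind of change as that from compound 1 to compound 2, made twice in all among the compounds shown; the surroundings are not identical, since in compound 2 the entering fluoro is para to a butoxycarbonyl group, whereas in compound 4 it is para to a propargyloxy group.

Among the compounds with values here, the one precedent is large. Compound 3 already gives a low number in this assay, however, and whether the fluoro step carries over in full on the second core cannot be told from one example. Compound 4 is therefore expected to show a step of a 5.3-fold lower number from compound 3 to compound 4 (0.72 log units; beyond the scatter), smaller than the earlier one because a 53-fold lower number from compound 1 to compound 2 (1.72 log units; beyond the scatter) started from a far higher number. Compound 4 is expected to give about 15 nM in this assay, between 4 nM and 50 nM.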

Compound 4, half-maximal inhibitory concentration: 15.9 nM
Beside the measured number, compound 4's estimate is 1.1-fold (0.03 log units) below it; the range from low to high includes it.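

On the core of compound 3, fluoro in place of hydrogen gives a 5.0-fold lower number from compound 3 to compound 4 (0.70 log units; beyond the scatter), so in this assay the change keeps the direction seen on the core of compound 1 but not its size: the same change on two cores in this assay, a 53-fold lower number (1.72 log units; beyond the scatter) from compound 1 to compound 2 and a 5.0-fold lower number (0.70 log units; beyond the scatter) from compound 3 to compound 4, 11-fold (1.02 log units) apart, beyond the scatter of two such steps

Read the other way round, propargyloxy in place of butoxycarbonyl gives a 4.3-fold lower number from compound 2 to compound 4 (0.63 log units; beyond the scatter), and this change also keeps its direction while losing much of its size: the same change on two cores in this assay, a 45-fold lower number (1.65 log units; beyond the scatter) from compound 1 to compound 3 and a 4.3-fold lower number (0.63 log units; beyond the scatter) from compound 2 to compound 4, 11-fold (1.02 log units) apart, beyond the scatter of two such steps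

Both comparisons rest on the same four compounds, so they are one observation seen from two sides rather than independent findings; they show that in this set the two changes do not simply add up and that a step measured on one core is a poor guide to its size on the other, but they do not show why, nor which size a further core would give.

The compounds shown leave open whether a group other than fluoro, such as a methyl group or a second chloro group, would behave in the same way at that place on the ring. They also leave open how the fluoro step would turn out with an allyloxy group or a carboxylic acid in place of the propargyloxy group.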